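Urea versus ester series at the urotensin-2 receptor

This account rests on a few compounds, and the source may have more. Where it says the series, first, only, none or still open, it means among the compounds named here.

Two pairs of compounds share the same dimethylaminopropyl chain with a chloro-substituted aryl group and differ in the linker to the second aryl group. Compound 1 `CN(C)CCC(OC(=O)c1ccc(C(F)(F)F)cc1)c1ccc(Cl)cc1` and compound 2 `CN(C)CCC(OC(=O)c1ccc(-c2ccccc2)cc1)c1ccc(Cl)cc1` carry an ester; compound 3 `CN(C)CCC(NC(=O)Nc1ccc(C(F)(F)F)cc1)c1ccc(Cl)cc1` and compound 4 `CN(C)CCC(NC(=O)Nc1ccc(-c2ccccc2)cc1)c1ccc(Cl)cc1` carry a urea. How the two cores differ between compound 1 and compound 3 is not broken down here.

In an assay on NIH3T3 cells with Urotensin-2 receptor (Homo sapiens) as the target (on this read-out lower numbers stand for an effect already at smaller amounts and higher numbers for an effect only at larger amounts of compound), compound 1 gives 1740 nM, and compound 2 gives 525 nM. The step of a 3.3-fold lower number from compound 1 to compound 2 (0.52 log units; beyond the scatter) is phenyl in place of trifluoromethyl on an aromatic carbon. Compound 3 gives 117 nM in this assay, the lowest number among the three measured compounds, with both steps to the others beyond the scatter.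

Compound 4 is not yet measured in this assay; it differs from compound 3 by phenyl in place of trifluoromethyl on an aromatic carbon, the same change that separates compound 1 from compound 2, at the same place. On that basis the step from compound 3 to compound 4 is expected to be a 2.9-fold lower number from compound 3 to compound 4 (0.47 log units; beyond the scatter), close to the earlier one. Compound 4 is thus estimated at 40 nM, with a range from 12 nM to 130 nM.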

Compound 4, half-maximal effective concentration: 145 nM
Compound 4: middle estimate off by 3.6-fold (0.56 log units), on the low side; the measured number lies above the stated range.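

In this assay the replacement of trifluoromethyl by phenyl does not carry over from the ester compounds to the urea compounds, and the two steps differ: the same change on two cores in this assay, a 3.3-fold lower number (0.52 log units; beyond the scatter) from compound 1 to compound 2 and a 1.2-fold higher number (0.09 log units; within the scatter) from compound 3 to compound 4, 4.1-fold (0.61 log units) apart, beyond the scatter of two such steps. Among the urea compounds the change gives a 1.2-fold higher number from compound 3 to compound 4 (0.09 log units; within the scatter), so the two cannot be told apart on this read-out. This rests on one pair of compounds for each linker, and it shows only that the size of this one step is not transferable between these two cores; it does not show why, or whether other groups at this place would behave the same way.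

Open, on these data alone, is whether a nitrile or a methoxy group in place of trifluoromethyl would also give different steps on the ester and urea linkers, and whether an amide linker would follow either pattern. Also open, as far as these compounds go, is how the same change behaves when the dimethylamino group gives way to a cyclic amine or the chain is made longer.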